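Replacing the Undecyl Group of Compound 3

The source may report more compounds than this note shows. Statements on the series, on what has been measured and on what is new or still open speak of the compounds shown alone.

In a functional assay on COLO 320 cells (Homo sapiens) for cytotoxicity, read by colony formation (a lower number here means a stronger inhibitor, a higher number a weaker inhibitor), three related compounds have been measured so far. Compound 3 `CCCCCCCCCCCC(=O)OC[C@H]1O[C@@H](O[C@@H]2OC=C(C(=O)OC)[C@H]3C[C@H](OC(C)=O)[C@H](C)[C@@H]23)[C@H](OC(C)=O)[C@@H](OC(C)=O)[C@@H]1OC(C)=O` gives 0.24 ug/mL and stands lowest of the three, clear of the scatter from both others. Higher numbers belong to compound 1 `COC(=O)C1=CO[C@@H](O[C@@H]2O[C@H](COC(c3ccccc3)(c3ccccc3)c3ccccc3)[C@@H](O)[C@H](O)[C@H]2O)[C@@H]2[C@@H](C)[C@@H](O)C[C@H]12` at 1.4 ug/mL and to compound 2 `CCC(=O)OC[C@H]1O[C@@H](O[C@@H]2OC=C(C(=O)OC)[C@H]3C[C@H](OC(C)=O)[C@H](C)[C@@H]23)[C@H](OC(C)=O)[C@@H](OC(C)=O)[C@@H]1OC(C)=O` at 4.86 ug/mL on this scale.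

Compound 4 `COC(=O)C1=CO[C@@H](O[C@@H]2O[C@H](COC(=O)C=C(C)C)[C@@H](OC(C)=O)[C@H](OC(C)=O)[C@H]2OC(C)=O)[C@@H]2[C@@H](C)[C@@H](OC(C)=O)C[C@H]12` is still unmeasured. Compared with compound 3 it carries 2-methylprop-1-en-1-yl in place of undecyl on a carbonyl carbon and the rest of the structure stays the same.

Going by the values given here, only one measured step bears on this change. It is a 20-fold lower number from compound 2 to compound 3 (1.31 log units; beyond the scatter) and it comes with nonyl in place of hydrogen on a saturated chain carbon, two bonds along the chain from a carbonyl carbon. That step is large and lies beyond the scatter. Among the compounds with values here, compound 4 also gives up the long chain, but its new group is not the one found in compound 2, so the comparison is only approximate. Going by a 20-fold lower number from compound 2 to compound 3 (1.31 log units; beyond the scatter) a move to a higher number is expected in this assay and it may be somewhat smaller than that step. The expected size is a 10-fold higher number from compound 3 to compound 4 (1.02 log units; beyond the scatter) in this estimate. For compound 4 the estimated value is 2.5 ug/mL with an expected range from 0.8 ug/mL to 8 ug/mL on this scale.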

Compound 4, half-maximal inhibitory concentration: 2.84 ug/mL
Estimate against measurement, compound 4: 1.1-fold (0.06 log units) below; the range from low to high includes it.
By their numbers in this assay, from the lowest: compound 3; then compound 1; then compounds 4 and 2 (each within the scatter of the next).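

Replacing undecyl with the much shorter 2-methylprop-1-en-1-yl on the carbonyl carbon gives a 12-fold higher number from compound 3 to compound 4 (1.07 log units; beyond the scatter) in this assay, so the low number of compound 3 does not survive with this second short group any more than it did with ethyl. The two short groups can also be compared directly: the change from ethyl to 2-methylprop-1-en-1-yl gives a 1.7-fold lower number from compound 2 to compound 4 (0.23 log units; within the scatter), and at this position in this assay, the double bond and the branching of the new group make no difference that can be told from the scatter. Among the three compounds that differ only in this group, the clear gain therefore belongs to undecyl alone, and the earlier single step could not show this because it compared undecyl with ethyl only.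

The compounds shown leave open where between the short groups and undecyl the number begins to fall, and whether a hexyl chain, a longer chain than undecyl or a phenyl group would keep it low. No measurement here explains why the undecyl compound stands apart.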